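Series notes: methylsulfanyl variant of compound 2

The source may report more compounds than this note shows. Statements on the series, on what has been measured and on what is new or still open speak of the compounds shown alone.

Measured in a functional assay on the whole organism with Rattus norvegicus as the target; a higher number here means that more compound is needed for the effect, a lower number that less compound is needed:
compound 1, `CCCc1ccc2nc(N)sc2c1`: compound 1 gives 6 mg/kg
compound 2, `CCn1c(=N)sc2cc(OC(F)(F)F)ccc21`: compound 2 gives 5 mg/kg

Compound 2 and compound 1 stand within the scatter of each other in this assay, so no order between them can be read. Compound 3 `CSCn1c(=N)sc2cc(OC(F)(F)F)ccc21` is not yet measured; it differs from compound 2 by methylsulfanyl in place of methyl on a saturated chain carbon bound to an aromatic nitrogen. For the measured compounds named here, no measured pair shows this change, so there is nothing to scale it by. A step beyond the scatter is not expected in either direction; the estimated step is a 1.2-fold higher number from compound 2 to compound 3 (0.08 log units; within the scatter). For compound 3 the estimate in this assay is 6 mg/kg, with a range of 2.5 mg/kg to 15 mg/kg.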

Compound 3, dose for half-maximal effect: 3 mg/kg
Estimate against measurement, compound 3: 2.0-fold (0.30 log units) above, within the range that was stated.
By their numbers in this assay, from the lowest: compounds 3, 2 and 1 (each within the scatter of the next).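

Measured in this assay the replacement of methyl by methylsulfanyl on a saturated chain carbon bound to an aromatic nitrogen gives a 1.7-fold lower number from compound 2 to compound 3 (0.22 log units; within the scatter) and so this position carries (methylsulfanyl)methyl in place of ethyl with no step beyond the scatter. This is the only change at this position among the compounds shown, so no trend along it can be read.

Going by these compounds, whether an amine, a carboxylic acid or a longer chain here would give a step beyond the scatter stays open. No measurement at hand bears on this result.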